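The compounds below may be only part of what the source reports. "The series", "measured", "known", "first", "only" and "open" are said of these compounds alone.

Of the compounds shown here, three sharing one core have been measured in a functional assay on TK-10 cells (Homo sapiens) for inhibition, read by sulforhodamine B assay, with a stated time of 48 h; a higher number here means a weaker inhibitor of growth, a lower number a stronger inhibitor of growth. Compound 1 `COc1cc(-c2cc(/C=C/C(=O)c3ccc(Cl)c(Cl)c3)[nH]n2)cc(OC)c1OC` gives 43200 nM, the highest of the three numbers, though its gap to compound 2 falls within the scatter and only its gap to compound 3 lies beyond it. Compound 2 `COc1ccc(-c2cc(/C=C/C(=O)c3ccc(N)cc3)[nH]n2)cc1OC` gives 23000 nM, and compound 3 `COc1ccc(-c2cc(/C=C/C(=O)c3ccc(N)cc3)[nH]n2)cc1` gives 13000 nM. Among the compounds with values here, the only step between measured compounds differing in one place is a 1.8-fold lower number from compound 2 to compound 3 (0.25 log units; within the scatter), a change at another part of the molecule. Compound 4 `COc1cc(-c2cc(/C=C/C(=O)c3ccc(F)c(F)c3)[nH]n2)cc(OC)c1OC` differs from compound 1 by 3,4-difluorophenyl in place of 3,4-dichlorophenyl on a carbonyl carbon. Within the data shown here, no measured step involves this exchange, so the expectation is simply that compound 4 stays near compound 1, with no step beyond the scatter. Compound 4 is therefore estimated at 43000 nM, between 15000 nM and 130000 nM, an expected step of a 1.0-fold lower number from compound 1 to compound 4 (0.00 log units; within the scatter).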

Compound 4, concentration for total growth inhibition: 7420 nM
Beside the measured number, compound 4's estimate is 5.8-fold (0.76 log units) above it; measured number outside the range, below it.
By their numbers in this assay, from the lowest: compounds 4, 3, 2 and 1 (each within the scatter of the next, the first and the last beyond it).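

In this assay, 3,4-difluorophenyl in place of 3,4-dichlorophenyl on a carbonyl carbon gives a 5.8-fold lower number from compound 1 to compound 4 (0.77 log units; beyond the scatter). Within the data shown here, this is the first single change here that lies beyond the scatter, and it shows that this position responds to which halogen its phenyl ring carries, although the two groups match in heavy-atom count and in hydrogen-bond donors and acceptors. Nothing available explains the difference between these two groups.

From the compounds shown here alone, it remains open how an unsubstituted phenyl or a phenyl carrying trifluoromethyl or nitrile would compare at this carbonyl carbon.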